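This account rests on a few compounds, and the source may have more. Where it says the series, first, only, none or still open, it means among the compounds named here.

Measured so far in a functional assay on cells for negative allosteric modulation of metabotropic glutamate receptor 5 (Homo sapiens), read by fluorescence and calcium flux, with a stated time of 20 min; on this read-out higher numbers stand for weaker inhibition and lower numbers for stronger inhibition:
compound 1 `O=S(=O)(c1ccc(F)c(Cl)c1)c1cnc2cc(F)ccc2c1-c1ccc(Cl)cc1`: 27 nM
compound 2 `O=S(=O)(c1cc(F)cc(F)c1)c1cnc2cc(F)ccc2c1-c1cccc(F)c1`: 74 nM
compound 3 `O=S(=O)(c1cc(Cl)cc(Cl)c1)c1cnc2c(F)cccc2c1-c1ccc(F)cc1`: 25 nM

Compound 1 holds the second highest of the three numbers. Compound 3 lies within the scatter of it, while compound 2 stands beyond the scatter at the higher end. Going by the values given here, no pair of measured compounds differs in only one place, so no single-change step is available as a guide.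

Compound 4 `O=S(=O)(c1cc(Cl)cc(Cl)c1)c1cnc2cc(F)ccc2c1-c1ccc(Cl)cc1` is not yet measured. It differs from compound 1 in one place: 3,5-dichlorophenyl in place of 3-chloro-4-fluorophenyl on a sulfonyl sulfur. Compound 3 also carries 3,5-dichlorophenyl on its sulfonyl sulfur and its number sits close to that of compound 1. A step of a 1.1-fold lower number from compound 1 to compound 4 (0.05 log units; within the scatter) is therefore expected, that is, none beyond the scatter in either direction. Compound 4 is estimated at 24 nM, with a range from 9 nM to 65 nM.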

Compound 4, half-maximal inhibitory concentration: 94 nM
Compound 4: middle estimate off by 3.9-fold (0.59 log units), on the low side; measured number above the stated range.
By their numbers in this assay, from the lowest: compounds 3 and 1 (each within the scatter of the next); then compounds 2 and 4 (each within the scatter of the next).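

The aryl group on the sulfonyl sulfur now has its first single-change step. In this assay, 3,5-dichlorophenyl in place of 3-chloro-4-fluorophenyl gives a 3.5-fold higher number from compound 1 to compound 4 (0.54 log units; beyond the scatter) and lies beyond the scatter, so this position affects the read-out with the rest of compound 1 held constant. No measured information on the compounds bears on the reason for this step.

As far as these compounds go, whether the step would keep its size with a different group on the shared core remains open. So does the effect of a methoxy group or a nitrile on the phenyl ring at this sulfonyl sulfur.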